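A few compounds are considered here, and "the series" means these few. Any claim that something is new, unique, unknown or untested is made for them only; others in the source may bear on it.

Measured so far in an assay on HEK293 cells for positive allosteric modulation of metabotropic glutamate receptor 3 (Rattus norvegicus), read by thallium flux, with a stated time of 2.5 min; on this read-out lower numbers stand for smaller maximal responses and higher numbers for larger maximal responses:
- compound 1, `Cc1c(OCCCCOc2ccc(F)c(C(=O)O)c2)ccc(C(=O)CC2CCCC2)c1O`: 98.4%
- compound 2, `CCCC(=O)c1ccc(OCCCCOc2ccc(F)c(C(=O)O)c2)c(C)c1O`: 56.9%
- compound 3, `Cc1c(OCCCCOc2ccc(F)c(C(=O)O)c2)ccc(C(=O)CC(C)(C)C)c1O`: 102%

Among these three numbers compound 1 stands second highest. Its nearest neighbour is compound 3, with a number 3.6 percentage points higher from compound 1 to compound 3 (within the scatter); its furthest is compound 2, with a number 41.5 percentage points lower from compound 1 to compound 2 (beyond the scatter). Between the other two, a number 45.1 percentage points higher from compound 2 to compound 3 (beyond the scatter). All three measured steps alter only the group on the saturated chain carbon bound to the carbonyl carbon, at the far end of the shared core from the acid-bearing ring.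

Compound 4, `Cc1c(OCCCCOc2ccc(C(=O)O)cc2F)ccc(C(=O)CC2CCCC2)c1O`, is built differently. Compared with compound 1, the change is 4-carboxy-2-fluorophenyl in place of 3-carboxy-4-fluorophenyl on an oxygen on a saturated carbon. The two compounds therefore share every atom and differ only in how the carboxylic acid and the fluorine are arranged on that ring. Within the data shown here, none of the measured steps touches this part of the molecule, so no measured step bears directly on this change; the three values only show the range this series has reached in this assay. As far as these compounds go, since the rearranged ring is untested, the step from compound 1 to compound 4 is expected to be modest, a number 13.4 percentage points lower from compound 1 to compound 4 (beyond the scatter), with wide uncertainty. The maximal response of compound 4 is estimated at 85%, within a range from 50% to 110%.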

Compound 4, largest response reached (reported as percent of maximum), in percent of the reference or control that the assay uses: 31.2%
For compound 4 the middle estimate is 53.8 percentage points above the measured one; measured number outside the range, below it.
By their numbers in this assay, from the lowest: compound 4; then compound 2; then compounds 1 and 3 (each within the scatter of the next).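

The earlier compounds shown here changed only the group on the saturated chain carbon bound to the carbonyl carbon, so they said nothing about the acid-bearing ring. In this assay, 4-carboxy-2-fluorophenyl in place of 3-carboxy-4-fluorophenyl gives a number 67.2 percentage points lower from compound 1 to compound 4 (beyond the scatter) and thus shows that the maximal response depends strongly on how the carboxylic acid and the fluorine are arranged on this ring, even though no atom is gained or lost. Nothing available accounts for the size of this step.

The compounds shown leave open whether the carboxylic acid or the fluorine drives this loss, which a phenyl ring carrying only the carboxylic acid could help separate. As far as these compounds go, it also remains open whether the same rearrangement would have a similar effect with tert-butyl in place of cyclopentyl.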